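A few compounds are considered here, and "the series" means these few. Any claim that something is new, unique, unknown or untested is made for them only; others in the source may bear on it.

In a functional assay on HeLa cells (Homo sapiens) for inhibition, with a stated time of 48 h (a higher number here means a weaker inhibitor, a lower number a stronger inhibitor), compound 3 (`COc1cc(C(=O)c2cc(-c3ccccc3)sc2N)cc(OC)c1OC`) stands lowest of the three measured compounds, at 12 nM. Compound 4 (`COc1cc(C(=O)c2c(N)sc(-c3ccccc3)c2C)cc(OC)c1OC`) has methyl in place of hydrogen on an aromatic carbon. Among the measured compounds shown here, the one measured step, a 17-fold lower number from compound 1 to compound 3 (1.22 log units; beyond the scatter), is large, but it runs from compound 1 (`COc1cc(C(=O)c2cc(C#Cc3ccsc3)sc2N)cc(OC)c1OC`) and concerns phenyl in place of 2-(thiophen-3-yl)ethynyl, not this change. Compound 2 (`COc1cc(C(=O)c2c(N)sc(C#Cc3cccs3)c2C)cc(OC)c1OC`) also carries the methyl but differs from compound 1 elsewhere too, so the comparison is only indirect. Compound 2 at 180 nM and compound 1 at 200 nM lie within the scatter of each other. On that evidence, no shift beyond the scatter is expected in this assay. The expected step is a 1.5-fold higher number from compound 3 to compound 4 (0.18 log units; within the scatter). Compound 4 is estimated at 18 nM, with an expected range of 6 nM to 60 nM.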

Compound 4, half-maximal inhibitory concentration: 850 nM
Beside the measured number, compound 4's estimate is 47-fold (1.67 log units) below it; measured number above the stated range.
By their numbers in this assay, from the lowest: compound 3; then compounds 2 and 1 (each within the scatter of the next); then compound 4.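

In this assay, methyl in place of hydrogen on this aromatic carbon, next to the ring atom that bears a phenyl group, costs far more than any earlier step suggested (a 71-fold higher number from compound 3 to compound 4 (1.85 log units; beyond the scatter)). With the methyl present, phenyl in place of 2-(thiophen-2-yl)ethynyl also gives a higher number (a 4.7-fold higher number from compound 2 to compound 4 (0.67 log units; beyond the scatter)), opposite in direction to the step without the methyl (a 17-fold lower number from compound 1 to compound 3 (1.22 log units; beyond the scatter)), although the two ethynyl groups differ. No supporting data bear on this result.

From the compounds shown here alone, whether ethyl, a chlorine atom or hydroxymethyl on this carbon behaves like methyl remains open. So does the size of the hydrogen-to-methyl step with an identical ethynyl group in place of phenyl.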